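This account rests on a few compounds, and the source may have more. Where it says the series, first, only, none or still open, it means among the compounds named here.

Series notes. The shared core `C=C1C[C@]23C[C@@]1(O)CC[C@H]2c1ccc(O)c(C)c1[C@@H]3Cn1cc(-c2ccccn2)nn1` of compound 3 carries a pyridin-2-yl on the five-membered aromatic ring with 3 nitrogen. In a functional assay on MCF7 cells (Homo sapiens) for cytotoxicity, read by MTT assay, with a stated time of 4 days (on this read-out higher numbers stand for weaker inhibition and lower numbers for stronger inhibition), compound 3 gives > 20000 nM, which is a limit of the assay and not a number. Compound 1 `C=C1C[C@]23C[C@@]1(O)CC[C@H]2c1cc(Br)c(O)c(C)c1[C@@H]3Cn1cc(-c2ccccn2)nn1` carries bromo on an aromatic carbon in addition. In this assay compound 1 gives > 20000 nM, again a limit. The step that the two limits leave unreadable from compound 1 to compound 3 therefore cannot be read. Compound 2 `C=C1C[C@]23C[C@@]1(O)CC[C@H]2c1ccc(O)c(C)c1[C@@H]3Cn1cc(-c2ccc(C(F)(F)F)cc2)nn1` carries 4-(trifluoromethyl)phenyl in place of pyridin-2-yl and in this assay gives 12400 nM. The step of an at least 1.6-fold higher number from compound 2 to compound 3 (0.20 log units; that floor lies within the scatter) is the only readable one, and its floor follows from the limit of > 20000 nM in this assay, at which 2 of the 3 values shown sit. Among the compounds with values here, compound 3 thus stands at the limit; the one recorded number in the set belongs to compound 2.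

Compound 4 `C=C1C[C@]23C[C@@]1(O)CC[C@H]2c1ccc(O)c(C)c1[C@@H]3Cn1cc(-c2ccc(F)cc2)nn1` differs from compound 3 as follows: 4-fluorophenyl in place of pyridin-2-yl on an aromatic carbon. The step that bears on it is an at least 1.6-fold higher number from compound 2 to compound 3 (0.20 log units; that floor lies within the scatter), run in reverse: a six-membered aromatic ring of carbon only returns in place of pyridin-2-yl, here carrying fluorine rather than trifluoromethyl. Within the data shown here, no measured step separates 4-fluorophenyl from 4-(trifluoromethyl)phenyl. The expected step is an at least 1.5-fold lower number from compound 3 to compound 4 (0.18 log units; that floor lies within the scatter), a lower number in this assay. Compound 4 is expected at 13000 nM, between 5000 nM and 30000 nM, with a real chance that only the limit is returned.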

Compound 4, half-maximal inhibitory concentration: > 20000 nM
Compound 4 gave a limit, no number; the forecaster's own chance of this, stated with the estimate: 40%; middle value at least 1.5-fold (0.18 log units) away from the limit.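

Putting a six-membered aromatic ring of carbon only back on this aromatic carbon of the five-membered aromatic ring with 3 nitrogen is not enough to give a recorded number in this assay: compound 4 has such a ring and still returns only a limit, as compound 3 with pyridin-2-yl does, so the step between those two cannot be read. Fluoro in place of trifluoromethyl gives an at least 1.6-fold higher number from compound 2 to compound 4 (0.20 log units; that floor lies within the scatter), so compound 2, the only compound with a recorded number, is not shown to be separated from compound 4 beyond the scatter. What can be read at this position therefore remains bounded by a single limit: the limit of > 20000 nM in this assay, at which 3 of the 4 values shown sit.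

Still open, as far as these compounds go, is whether any group at this position gives a value clearly clear of that limit, and how far compound 2 really stands from compound 3 and compound 4. Also open, from the compounds shown here alone, is what an amine or a carboxylic acid on the phenyl ring, or a longer chain in place of the ring, would give in this assay.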